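Tetrazole for Carboxylic Acid on a Branched Chain

This account rests on a few compounds, and the source may have more. Where it says the series, first, only, none or still open, it means among the compounds named here.

Compound 1 `CCCc1c(COc2ccc(C(=O)CCC(=O)O)cc2)ccc(C(C)=O)c1O`: 18.2 mg/kg
Compound 2 `CCCc1c(COc2ccc(C(=O)CCc3nnn[nH]3)cc2)ccc(C(C)=O)c1O`: 10.1 mg/kg
Compound 3 `CCc1c(COc2ccc(C(=O)CC(C)(C)CC(=O)O)cc2)ccc(C(C)=O)c1O`: 1.4 mg/kg

Of the compounds shown here, three have so far been measured in an in vivo functional assay on the whole organism (Rattus norvegicus) with cysteinyl leukotriene receptor (Homo sapiens) as the target; a lower number here means that less compound is needed, a higher number that more compound is needed for the effect. Compound 1 and compound 2 share a core and differ by 1H-tetrazol-5-yl in place of carboxy on a saturated chain carbon, two bonds along the chain from a carbonyl carbon; that change gave a 1.8-fold lower number from compound 1 to compound 2 (0.26 log units; within the scatter). The difference between the core of compound 1 and the core of compound 3 is not broken down here; the values show that compound 3 gives the lowest number of the three in this assay, beyond the scatter from both compound 1 and compound 2.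

Compound 4 `CCc1c(COc2ccc(C(=O)CC(C)(C)Cc3nnn[nH]3)cc2)ccc(C(C)=O)c1O` has not yet been measured. It differs from compound 3 by 1H-tetrazol-5-yl in place of carboxy on a saturated chain carbon, three bonds along the chain from a carbonyl carbon. Within the data shown here, this is the same kind of change as the one from compound 1 to compound 2, though not the same: there the group sits two bonds along the chain from a carbonyl carbon, here three bonds along the chain from a carbonyl carbon.

For compound 4 a step of about a 1.6-fold lower number from compound 3 to compound 4 (0.19 log units; within the scatter) in this assay is expected, because the earlier change gave a 1.8-fold lower number from compound 1 to compound 2 (0.26 log units; within the scatter). Compound 4 is therefore estimated at 0.9 mg/kg, between 0.4 mg/kg and 2.5 mg/kg.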

Compound 4, dose for half-maximal effect: 1.1 mg/kg
For compound 4 the middle estimate is 1.2-fold (0.09 log units) below the measured one; the measured number falls inside the stated range.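

In this assay, putting 1H-tetrazol-5-yl in place of carboxy on the branched chain gave a 1.3-fold lower number from compound 3 to compound 4 (0.10 log units; within the scatter), which leaves compound 3 and compound 4 indistinguishable in this measurement. The earlier step on the other core agrees with this one: the same change on two cores in this assay, a 1.8-fold lower number (0.26 log units; within the scatter) from compound 1 to compound 2 and a 1.3-fold lower number (0.10 log units; within the scatter) from compound 3 to compound 4, 1.4-fold (0.15 log units) apart, within the scatter of two such steps. In these two pairs the exchange therefore carried across both cores without a step that stands clear of the scatter, but this does not show that the change itself moves the number in either direction, and two pairs cannot show that it would behave the same way on other cores in the series.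

The compounds shown leave open whether another acid group, such as a sulfonic acid or an acyl sulfonamide, could take the place of carboxy on these chains. They also leave open how the chain length, the two methyl groups on the chain and the ethyl or propyl group on the core each contribute, as these never vary alone here.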